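The source may report more compounds than this note shows. Statements on the series, on what has been measured and on what is new or still open speak of the compounds shown alone.

Compound 3 `Cn1c(=O)n(C2OC(CO)[C@@H](O)[C@H]2O)c2nc(N)nc(O)c21` stands highest of the three measured compounds: in a functional assay on YAC-1 cells (Mus musculus) (on this read-out lower numbers stand for smaller maximal responses and higher numbers for larger maximal responses), compound 3 gives 72%. Compound 1 `Nc1nc(O)c2c(n1)n(C1OC(CO)[C@@H](O)[C@H]1O)c(=O)n2Cc1ccc(Cl)cc1` gives 27% in this assay, and compound 2 `N#Cc1ccc(Cn2c(=O)n(C3OC(CO)[C@@H](O)[C@H]3O)c3nc(N)nc(O)c32)cc1` gives 0%. Compound 4 `NC(=O)Cn1c(=O)n(C2OC(CO)[C@@H](O)[C@H]2O)c2nc(N)nc(O)c21` differs from compound 3 by carbamoyl in place of hydrogen on a saturated chain carbon bound to an aromatic nitrogen. For the measured compounds named here, two measured steps concern the same saturated chain carbon: a number 45 percentage points higher from compound 1 to compound 3 (beyond the scatter) and a number 72 percentage points higher from compound 2 to compound 3 (beyond the scatter). In both, removing a group from that carbon raised the maximal response strongly, so placing a group there again is expected to lower it. Because compound 3 gives 72% once those ring-bearing groups are gone and the entering carbamoyl has no ring, a smaller fall than either is expected, a number 27 percentage points lower from compound 3 to compound 4 (beyond the scatter). Compound 4 is therefore estimated at 45%, with a range from 15% to 75%.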

Compound 4, largest response reached (reported as maximal response), in percent of the reference or control that the assay uses: 42%
The estimate for compound 4 lay 3 percentage points above the measured number; low and high end bracket the measured number.
By their numbers in this assay, from the lowest: compound 2; then compound 1; then compound 4; then compound 3.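

Carbamoyl, which has no ring, also lowers the number on this saturated chain carbon in this assay, with a number 30 percentage points lower from compound 3 to compound 4 (beyond the scatter). The fall therefore does not depend on a ring-bearing group. Carbamoyl still stands higher than both aryl-bearing groups: carbamoyl in place of 4-chlorophenyl gives a number 15 percentage points higher from compound 1 to compound 4 (beyond the scatter), and carbamoyl in place of 4-cyanophenyl gives a number 42 percentage points higher from compound 2 to compound 4 (beyond the scatter).

Open, as far as these compounds go, is where an amine, a carboxylic acid or a longer chain at this carbon would fall relative to compound 3 and compound 4. No evidence at hand bears on why these steps run as they do.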